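Side chain on the aromatic nitrogen: compound 3

The source may report more compounds than this note shows. Statements on the series, on what has been measured and on what is new or still open speak of the compounds shown alone.

Among the compounds with values here, in a functional assay on A549 cells (Homo sapiens) for cytotoxicity, read by MTT assay, with a stated time of 72 h (a lower number here means a stronger inhibitor, a higher number a weaker inhibitor), compound 2 (`O=C1c2c[n+]([O-])c3ccccc3c2C(=O)c2[nH]c3ccccc3c21`) gives 320 nM, the lowest of the two numbers so far, and compound 1 (`O=C1c2c[n+]([O-])c3ccccc3c2C(=O)c2c1c1ccccc1n2Cc1cn(CC(O)CO)nn1`) gives 880 nM. The next structure is compound 3 (`O=C1c2c[n+]([O-])c3ccccc3c2C(=O)c2c1c1ccccc1n2CCCN1CCC(O)CC1`), which differs from compound 2 by 3-(4-hydroxypiperidin-1-yl)propyl in place of hydrogen on an aromatic nitrogen. Within the data shown here, only one measured step bears on this change: a 2.8-fold lower number from compound 1 to compound 2 (0.44 log units; beyond the scatter), a modest step involving a different side chain on the same nitrogen. Read in reverse, it points to a higher number with substitution, though it is a single precedent. The expected step, of similar modest size, is a 2.2-fold higher number from compound 2 to compound 3 (0.34 log units; beyond the scatter). For compound 3, the estimated value in this assay is 700 nM, with an expected range of 230 nM to 2000 nM.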

Compound 3, half-maximal inhibitory concentration: 350 nM
Beside the measured number, compound 3's estimate is 2.0-fold (0.30 log units) above it; measured number inside the range.
By their numbers in this assay, from the lowest: compounds 2 and 3 (each within the scatter of the next); then compound 1.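

In this assay there is a 1.1-fold higher number from compound 2 to compound 3 (0.04 log units; within the scatter) so 3-(4-hydroxypiperidin-1-yl)propyl on the aromatic nitrogen leaves the number of the unsubstituted compound 2 within the scatter. With a 2.5-fold lower number from compound 1 to compound 3 (0.40 log units; beyond the scatter) in the same assay, the higher number of compound 1 does not hold for every side chain at this position. No measurement shown explains either step. Still open, going by these compounds, is whether the hydroxyl matters, which an unsubstituted piperidine on the same propyl chain would address. On these data alone, a morpholine or a primary amine at the chain end also remains open.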